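Working notes: aminoamino for piperidin-1-yl on compound 3

The source may hold more compounds than are shown below. What is called first, only, known or untested is meant among the compounds shown, and "the series" means these compounds.

Compound 3 `Cc1nc2cc(Br)ccc2nc1N1CCCCC1` is the starting point of this step. In a functional assay on MCF7 cells (Homo sapiens) for inhibition, read by sulforhodamine B assay, with a stated time of 72 h (a lower number here means a stronger inhibitor, a higher number a weaker inhibitor), compound 3 gives 0.0336 ug/mL, the highest of the three numbers recorded so far. Compound 1 `COc1ccc(/C=C/c2nc3cc(Br)ccc3[nH]c2=O)cc1` gives 0.00006 ug/mL in this assay, and compound 2 `Cc1nc2cc(Br)ccc2n(CC(=O)NN)c1=O` gives 0.00001 ug/mL; both lie far below compound 3, beyond the scatter, but neither differs from compound 3 in a single place, so these gaps are only what the two numbers show and do not define a step.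

Compound 4 `Cc1nc2cc(Br)ccc2nc1NN` is the untested analogue of compound 3. The change is aminoamino in place of piperidin-1-yl on an aromatic carbon. For the measured compounds named here, no single-site step has been measured, so the size of the effect in this assay is uncertain. Compound 2, which also carries a nitrogen-nitrogen group, gives 0.00001 ug/mL in this assay, the only hint that such a group is well tolerated. The number for compound 4 is expected to fall by a 4.2-fold lower number from compound 3 to compound 4 (0.62 log units; beyond the scatter), a modest step. Compound 4 is estimated at 0.008 ug/mL, within a range from 0.0004 ug/mL to 0.15 ug/mL.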

Compound 4, half-maximal inhibitory concentration: 0.0243 ug/mL
Compound 4: middle estimate off by 3.0-fold (0.48 log units), on the low side, and the stated range covers the measured number.
By their numbers in this assay, from the lowest: compound 2; then compound 1; then compounds 4 and 3 (each within the scatter of the next).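

In this assay, for the compounds shown here, the first single-site step reads a 1.4-fold lower number from compound 3 to compound 4 (0.14 log units; within the scatter), so piperidin-1-yl and aminoamino on this aromatic carbon cannot be told apart. At this position, therefore, the six-membered non-aromatic ring can give way to an open group with more hydrogen-bond donors without a readable shift in the number, although this rests on a single pair. Nothing on hand explains why the number holds across this change.

From the compounds shown here alone, whether a primary amine, a morpholine ring or a longer chain ending in a carboxylic acid on the same carbon would move the number remains open. Going by these compounds alone, it is also open whether the methyl group on the neighbouring ring position contributes to the number, as no step at that place can be read.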